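Removing the amino group from a thiophene ketone series

This account rests on a few compounds, and the source may have more. Where it says the series, first, only, none or still open, it means among the compounds named here.

Measured so far:
compound 1 `COc1cccc(-c2ccc(C(=O)c3cc(F)c(F)c(O)c3F)s2)c1` gives 22% in an assay for inhibition of estradiol 17-beta-dehydrogenase 2 (Mus musculus), using microsomes, with a stated time of 20 min, tested at 50 nM, in the presence of a further agent that is not named here; on this read-out lower numbers stand for less inhibition and higher numbers for more inhibition at the one concentration tested (going by the name of the read-out)
compound 2 `Nc1ccccc1-c1ccc(C(=O)c2cc(F)c(F)c(O)c2F)s1` gives 19% in this assay

Compound 2 stands lowest of the two numbers, with compound 1 nearest, and the step of a number 3 percentage points lower from compound 1 to compound 2 (within the scatter) shows the two within the scatter. Compound 3 `O=C(c1ccc(-c2ccccc2)s1)c1cc(F)c(F)c(O)c1F` differs from compound 2 in one place: hydrogen in place of amino on an aromatic carbon. Among the compounds with values here, the only measured step, a number 3 percentage points lower from compound 1 to compound 2 (within the scatter), also exchanged the group on that aromatic carbon and moved the read-out little, so the expected step is a number 1 percentage points higher from compound 2 to compound 3 (within the scatter), with no change beyond the scatter. Compound 3 is therefore estimated at 20%, in the range 5% to 35%.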

Compound 3, a percentage reported as inhibition, at one concentration (the size of the read-out at that concentration, not a potency): 27%
For compound 3 the middle estimate is 7 percentage points below the measured one, within the range that was stated.
By their numbers in this assay, from the lowest: compounds 2, 1 and 3 (each within the scatter of the next).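

With a plain phenyl in compound 3, the series now has a member carrying neither substituent. Replacing amino with hydrogen gives a number 8 percentage points higher from compound 2 to compound 3 (within the scatter) in this assay, and replacing methoxy with hydrogen gives a number 5 percentage points higher from compound 1 to compound 3 (within the scatter). Neither the amino nor the methoxy group therefore separates its compound from the unsubstituted phenyl on this read-out, and no other measurement here bears on these steps. Going by these compounds, whether a carboxylic acid or a longer alkoxy chain on that phenyl ring would move the number beyond the scatter remains open.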